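The source may hold more compounds than are shown below. What is called first, only, known or untested is meant among the compounds shown, and "the series" means these compounds.

Working notes on the series in an assay on VSM-A10 cells for antagonist activity at Endothelin-1 receptor (Rattus norvegicus); on this read-out lower numbers stand for stronger inhibition and higher numbers for weaker inhibition. Three compounds have numbers. Compound 1 `CCOC(=O)C(C)Nc1cccc2c(S(=O)(=O)Nc3onc(C)c3C)cccc12` gives 400 nM in this assay and stands second highest of the three. Going by the values given here, compound 3 `Cc1onc(NS(=O)(=O)c2cccc3c(N(C)C)cccc23)c1C` gives 60 nM in this assay, and compound 2 `Cc1noc(NS(=O)(=O)c2ccc(NC(=O)CN)cc2)c1C` gives 6500 nM in this assay; no single step between measured compounds is available, so only the values themselves are compared. Compound 4 `Cc1noc(NS(=O)(=O)c2cccc3c(N/C(S)=N/c4ccccc4)cccc23)c1C` is not yet measured. It differs from compound 1 by a group of 9 heavy atoms (7 carbon, 1 nitrogen, 1 sulfur; one six-membered aromatic ring of carbon only) in place of a group of 7 heavy atoms (5 carbon, 2 oxygen; no ring), on a nitrogen on an aromatic ring. The value of compound 3, 60 nM, shows that the core of compound 1 tolerates another group on that nitrogen with a lower number, so a moderate step down is expected, possibly not beyond the scatter. Compound 4 is estimated at 180 nM, range 40 nM to 800 nM, an expected step of a 2.2-fold lower number from compound 1 to compound 4 (0.35 log units; beyond the scatter).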

Compound 4, half-maximal inhibitory concentration: 150 nM
Beside the measured number, compound 4's estimate is 1.2-fold (0.08 log units) above it, and the stated range covers the measured number.
By their numbers in this assay, from the lowest: compound 3; then compound 4; then compound 1; then compound 2.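

In this assay, a nitrogen on an aromatic ring accepts a group with a six-membered aromatic ring of carbon only in place of 1-(ethoxycarbonyl)ethyl, giving a 2.7-fold lower number from compound 1 to compound 4 (0.43 log units; beyond the scatter). Going by these compounds alone, this is the first single-place step at this position, and it shows that 1-(ethoxycarbonyl)ethyl is not needed to keep the number this low. No measured evidence bears on the reason for the step. The compounds shown leave open which part of the entering group goes with the step, and how a carboxylic acid or a longer alkyl chain on that nitrogen would read.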